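The source may hold more compounds than are shown below. What is called first, only, known or untested is meant among the compounds shown, and "the series" means these compounds.

Compound 1, `C[C@]1(c2ccccc2)OC[C@H]([C@@H]2CCCCN2)O1`, is measured in a functional assay (brain) for displacement of a labelled ligand, with Rattus norvegicus as the target (a higher number here means a weaker inhibitor, a lower number a stronger inhibitor), where compound 1 gives 847 nM. Compound 2, `CCC[C@]1(c2ccccc2)OC[C@H]([C@@H]2CCCCN2)O1`, carries one change relative to compound 1, (ethyl in place of hydrogen on a saturated chain carbon bound to a saturated ring carbon), and in this assay compound 2 gives 69 nM. This is a large step, a 12-fold lower number from compound 1 to compound 2 (1.09 log units; beyond the scatter).

Compound 3, `CN[C@@H](C)[C@H]1COC(c2ccccc2)(c2ccccc2)O1`, rests on a different core; how the core of compound 3 differs from the core of compound 1 is not broken down here. In this assay compound 3 gives 703 nM, a number close to that of compound 1 and within the usual scatter of it, while the number of compound 2 stands well beyond the scatter below both.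

Compound 4, `CCC[C@H](NC)[C@H]1COC(c2ccccc2)(c2ccccc2)O1`, is not yet measured. It differs from compound 3 by ethyl in place of hydrogen on a saturated chain carbon, two bonds along the chain from an amine nitrogen and a saturated ring carbon. Within the data shown here, this is the same kind of change as the one from compound 1 to compound 2, but not the same: in the pair of compound 1 and compound 2 the ethyl enters on a saturated chain carbon bound to a saturated ring carbon, whereas in compound 4 it enters on a saturated chain carbon two bonds along the chain from an amine nitrogen and a saturated ring carbon. Among the measured compounds shown here, on only one earlier example, and on a different core, a step of similar direction is expected from compound 3 to compound 4 in this assay, namely a 5.9-fold lower number from compound 3 to compound 4 (0.77 log units; beyond the scatter), because the step of a 12-fold lower number from compound 1 to compound 2 (1.09 log units; beyond the scatter) was large and beyond the scatter. For the measured compounds named here, compound 4 is therefore estimated at 120 nM, with a range from 35 nM to 450 nM reflecting the single precedent.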

Compound 4, inhibition constant: 7000 nM
Compound 4: the middle estimate sits 58-fold (1.77 log units) below what was measured; measured number above the stated range.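

In this assay, the same change runs the opposite way on the core of compound 3, giving a 10-fold higher number from compound 3 to compound 4 (1.00 log units; beyond the scatter). Set beside the earlier step, it shows that the gain seen on the core of compound 1 did not carry over to the core of compound 3, and that the effect of this change in the series depends on where it is made: the same change on two cores in this assay, a 12-fold lower number (1.09 log units; beyond the scatter) from compound 1 to compound 2 and a 10-fold higher number (1.00 log units; beyond the scatter) from compound 3 to compound 4, 120-fold (2.09 log units) apart, beyond the scatter of two such steps

This does not show a general rule for either core, as each direction rests on a single pair of compounds. Nor does it separate the influence of the core from that of the place, since the ethyl enters on a saturated chain carbon bound to a saturated ring carbon in one pair, and on a saturated chain carbon two bonds along the chain from an amine nitrogen and a saturated ring carbon in the other.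

The compounds shown leave open how either core responds to an ethyl or a butyl in place of the propyl, so it is unknown whether each trend is gradual or limited to this one chain. They also leave open whether the core of compound 3 would respond differently if it carried the amine of compound 1.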